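This account rests on a few compounds, and the source may have more. Where it says the series, first, only, none or still open, it means among the compounds named here.

Of the compounds shown here, three sharing one core have been tested in a functional assay, with a stated time of 20 min, tested at 10 uM; a lower number here means a weaker effect, a higher number a stronger effect of the compound at the concentration tested. Compound 1 `COc1cc(/C=C/C(=O)C2=C(/C=C/c3ccc(O)c(OC)c3)NC(=S)NC2c2ccccc2O)ccc1O` carries a 2-hydroxyphenyl group on a saturated ring carbon, and in this assay compound 1 gives 70.8%. Compound 2 `COc1cc(/C=C/C(=O)C2=C(/C=C/c3ccc(O)c(OC)c3)NC(=S)NC2c2ccc(N(C)C)cc2)ccc1O` carries a 4-(dimethylamino)phenyl group on that carbon, and in this assay compound 2 gives 59%. Compound 3 `COc1cc(/C=C/C(=O)C2=C(/C=C/c3ccc(O)c(OC)c3)NC(=S)NC2c2c(Cl)cccc2Cl)ccc1O` carries a 2,6-dichlorophenyl group there, and in this assay compound 3 gives 20.2%, the lowest of the three numbers. The steps down to it are a number 50.6 percentage points lower from compound 1 to compound 3 (beyond the scatter) and a number 38.8 percentage points lower from compound 2 to compound 3 (beyond the scatter), both beyond the scatter, whereas the change a number 11.8 percentage points lower from compound 1 to compound 2 (beyond the scatter) is smaller.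

Compound 4 `COc1cc(/C=C/C(=O)C2=C(/C=C/c3ccc(O)c(OC)c3)NC(=S)NC2c2ccccc2Cl)ccc1O` differs from compound 3 in one place: hydrogen in place of chloro on an aromatic carbon. Within the data shown here, no measured step removes a single chloro, so the expectation rests on the two steps that bear on the 2,6-dichlorophenyl group, a number 50.6 percentage points lower from compound 1 to compound 3 (beyond the scatter) and a number 38.8 percentage points lower from compound 2 to compound 3 (beyond the scatter), which show that this group goes with the lowest activity, while compound 1 with a different group on the same carbon lies far higher. Keeping only one chloro is expected to recover part of that loss, and the expected step is a number 24.8 percentage points higher from compound 3 to compound 4 (beyond the scatter). The estimate for compound 4 is 45%, within a range from 20% to 70%.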

Compound 4, a percentage reported as activity, at one concentration (the size of the read-out at that concentration, not a potency): 21.2%
Compound 4: the middle estimate sits 23.8 percentage points above what was measured; the measured number falls inside the stated range.
By their numbers in this assay, from the lowest: compounds 3 and 4 (each within the scatter of the next); then compound 2; then compound 1.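

In this assay, taking one chloro away from the 2,6-dichlorophenyl group gives a number 1 percentage points higher from compound 3 to compound 4 (within the scatter), so the low number does not depend on having two chloro groups, and the 2-chlorophenyl group with its single chloro goes with it just the same. The other two steps agree: a number 37.8 percentage points lower from compound 2 to compound 4 (beyond the scatter) and a number 49.6 percentage points lower from compound 1 to compound 4 (beyond the scatter) are both large, like the steps down to compound 3, and the second of them amounts to a single swap of hydroxy for chloro on the same aromatic carbon. At this position, then, the two chloro-bearing groups stand together, well apart from the 2-hydroxyphenyl and 4-(dimethylamino)phenyl groups, and no supporting measurement bears on the reason for this split.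

On these data alone, what remains open is whether the remaining chloro matters at all, or whether the hydroxy of compound 1 is what lifts the number, and a plain phenyl group, with hydrogen in place of that chloro, would separate the two readings. A methoxy or an amino group at that same place would further show how much the number depends on which group sits there.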